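Swapping a Dimethylpyrazole for Pyrrolidine: Expected Lipophilicity

The source may report more compounds than this note shows. Statements on the series, on what has been measured and on what is new or still open speak of the compounds shown alone.

Measured compounds:
Compound 1 `Cc1cc(C)n(-c2ccc(Cl)c(C(=O)NC(=O)Nc3nc4ccc(S(=O)(=O)CCCN5CCN(C)CC5)cc4s3)c2)n1` gives 2.5
Compound 2 `Cc1ccnn1-c1ccc(Cl)c(C(=O)NC(=O)Nc2nc3ccc(S(=O)(=O)C4CCN(C)CC4)cc3s2)c1` gives 2.6
Compound 3 `CN1CCC(S(=O)(=O)c2ccc3nc(NC(=O)NC(=O)c4cc(-n5cccn5)ccc4Cl)sc3c2)CC1` gives 2.5

In a physicochemical assay for lipophilicity (a lower number here means a more polar compound, a higher number a more lipophilic compound), compound 1 stands level with compound 3 at the digits shown, and compound 2 lies within the scatter of both, so the three measured values cannot be told apart. Compound 4 `CN1CCN(CCCS(=O)(=O)c2ccc3nc(NC(=O)NC(=O)c4cc(N5CCCC5)ccc4Cl)sc3c2)CC1` differs from compound 1 in one place: pyrrolidin-1-yl in place of 3,5-dimethyl-1H-pyrazol-1-yl on an aromatic carbon. Among the measured compounds shown here, the only measured step, a number 0.10 log units lower from compound 2 to compound 3 (within the scatter), concerns a different change and gives no direct guide to this one; it shows merely that one small alteration to the shared core left this assay unmoved. For the measured compounds named here, no measured pair covers a pyrrolidin-1-yl or a 3,5-dimethyl-1H-pyrazol-1-yl, so the expectation rests on the closeness of the three values already seen. For compound 4 the value in this assay is therefore expected to be 2.7, with a range of 2.2 to 3.2. That estimate corresponds to an expected step of a number 0.20 log units higher from compound 1 to compound 4 (within the scatter), judged to stay within the scatter.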

Compound 4, distribution coefficient: 3.1
Estimate against measurement, compound 4: 0.40 log units below; low and high end bracket the measured number.
By their numbers in this assay, from the lowest: compounds 1, 3 and 2 (each within the scatter of the next); then compound 4.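

In this assay, pyrrolidin-1-yl in place of 3,5-dimethyl-1H-pyrazol-1-yl gives a number 0.60 log units higher from compound 1 to compound 4 (beyond the scatter), so a change on this aromatic carbon can move the number beyond the scatter, which the earlier step, a number 0.10 log units lower from compound 2 to compound 3 (within the scatter), did not show. The number rises here even though the entering group is a non-aromatic ring with 5 heavy atoms and the leaving group an aromatic ring with 7, so a smaller heavy-atom count does not go with a lower number in this pair. Nothing available explains the rise.

This single step cannot separate the loss of aromaticity from the loss of a ring nitrogen or of the two methyl groups. Groups such as piperidin-1-yl, morpholin-4-yl or an amide-linked amine on the same carbon remain open, as does whether the step carries over to the core of compound 3.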